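Swapping diethylamino for pyrrolidin-1-yl on the carbonyl carbon

A few compounds are considered here, and "the series" means these few. Any claim that something is new, unique, unknown or untested is made for them only; others in the source may bear on it.

Going by the values given here, in a functional assay on A549 cells (Homo sapiens) for cytotoxicity, read by XTT assay, with a stated time of 72 h (on this read-out lower numbers stand for stronger inhibition and higher numbers for weaker inhibition), compound 3 (`CCN(CC)C(=O)c1ccc(-c2cc(C3=CC(=O)C=CC3=O)no2)s1`) gives 10000 nM, the only actual number among the measured compounds. Compound 1 (`CN(C)C(=O)c1ccc(-c2cc(C3=CC(=O)C=CC3=O)no2)s1`) reaches only a limit, > 30000 nM. Compound 2 (`O=C1C=CC(=O)C(c2cc(-c3ccc(C(=O)N4CCC(C(F)(F)F)CC4)s3)on2)=C1`) likewise reaches only a limit, > 30000 nM. Compound 4 (`O=C1C=CC(=O)C(c2cc(-c3ccc(C(=O)N4CCCC4)s3)on2)=C1`) carries pyrrolidin-1-yl in place of diethylamino on a carbonyl carbon. Among the compounds with values here, two measured steps bear on this change, an at least 3.0-fold lower number from compound 1 to compound 3 (0.47 log units; beyond the scatter) and an at least 3.0-fold lower number from compound 2 to compound 3 (0.47 log units; beyond the scatter). Both concern the same place on the molecule, and neither alternative group, with or without a ring, gives a number. The expected step in this assay is a 1.8-fold higher number from compound 3 to compound 4 (0.26 log units; within the scatter), towards weaker inhibition. Compound 4 could also land on (the limit of > 30000 nM in this assay, at which 2 of the 3 values shown sit). For compound 4 the estimate is 18000 nM, with an expected range from 7000 nM to 45000 nM.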

Compound 4, half-maximal inhibitory concentration: > 30000 nM
Compound 4 gave a limit, no number; the forecaster's own chance of this, stated with the estimate: 45%; at least 1.6-fold (0.22 log units) between middle value and limit.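

In this assay, going by these compounds alone, pyrrolidin-1-yl in place of diethylamino on the carbonyl carbon gives an at least 3.0-fold higher number from compound 3 to compound 4 (0.47 log units; beyond the scatter), so a change that keeps the same heavy atoms but adds a ring is enough to lose the only measured number. Among the amides shown, only compound 3 now gives a number, while compound 1, which has no ring, also stops at a limit. Compound 4 stops at the same limit, leaving its steps from compound 1 and compound 2 unreadable: the limit of > 30000 nM in this assay, at which 3 of the 4 values shown sit.

On these data alone, how far these limit compounds really lie from one another stays open. So does whether dipropylamino, a longer chain than diethylamino, would lower the number.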